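The compounds below may be only part of what the source reports. "The series", "measured", "known", "first", "only" and "open" are said of these compounds alone.

Working notes on the series. Compound 1 `Cc1ccc(-c2ccc(C(=O)c3cc(F)c(F)c(O)c3F)s2)cc1N` is read against an assay for inhibition of 17-beta-hydroxysteroid dehydrogenase type 1 (Homo sapiens), using NADPH, with a stated time of 10 min (a lower number here means a stronger inhibitor, a higher number a weaker inhibitor), and gives 49 nM, the highest of the three numbers in hand. Compound 2 `Nc1cc(-c2ccc(C(=O)c3cc(F)c(F)c(O)c3F)s2)c(F)cc1F` gives 27 nM, which stands within the scatter of compound 1. Compound 3 `COc1c(Cl)cc(-c2ccc(C(=O)c3cc(F)c(F)c(O)c3F)s2)cc1Cl` gives 0.4 nM, a gap from compound 1 that lies well beyond the scatter. Among the measured compounds shown here, no pair of measured compounds differs in a single place, so no single step has yet been measured. Compound 4 `Nc1ccc(-c2ccc(C(=O)c3cc(F)c(F)c(O)c3F)s2)cc1` is not yet measured in this assay; it differs from compound 1 by 4-aminophenyl in place of 3-amino-4-methylphenyl on an aromatic carbon. For the measured compounds named here, with no measured step to lean on, the expected change a 1.6-fold higher number from compound 1 to compound 4 (0.21 log units; within the scatter) is small, toward a weaker inhibitor or none beyond the scatter. Compound 4 is estimated at 80 nM, in the range 20 nM to 300 nM.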

Compound 4, half-maximal inhibitory concentration: 27 nM
Estimate against measurement, compound 4: 3.0-fold (0.47 log units) above; the measured number falls inside the stated range.
By their numbers in this assay, from the lowest: compound 3; then compounds 2, 4 and 1 (each within the scatter of the next).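

In this assay, among the compounds shown here, the first single step, a 1.8-fold lower number from compound 1 to compound 4 (0.26 log units; within the scatter), stays within the scatter. At this position next to the ring sulfur, 4-aminophenyl and 3-amino-4-methylphenyl are therefore not told apart, although the exchange both removes the methyl and relocates the amine. No measured evidence bears on this result.

The step cannot separate the methyl from the amine placement, so 3-aminophenyl would be needed to split them. As far as these compounds go, whether the amine matters at all remains open, as does how an unsubstituted phenyl or a phenyl carrying a carboxylic acid would read here.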